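A Second Methyl on the Chain, Lipophilicity Expected

This account rests on a few compounds, and the source may have more. Where it says the series, first, only, none or still open, it means among the compounds named here.

Compound 1 `CN/C(=N\C#N)NCc1ccc(Cl)nc1`, compound 2 `CCN/C(=N\C#N)NCc1ccc(Cl)nc1` and compound 3 `CN/C(=N\C#N)N(C)Cc1ccc(Cl)nc1` have been measured for lipophilicity, while compound 4 `CCN/C(=N\C#N)N(C)Cc1ccc(Cl)nc1` has not. In a physicochemical assay for lipophilicity, using the shake flask method, measured as octanol-water partition, at 23 degrees C (on this read-out lower numbers stand for lower lipophilicity and higher numbers for higher lipophilicity), compound 1 gives 0.84, compound 2 gives 0.86 and compound 3 gives 0.78. Compound 2 differs from compound 1 by methyl in place of hydrogen on a saturated chain carbon bound to an amine nitrogen, and that change made a step of a number 0.02 log units higher from compound 1 to compound 2 (within the scatter). Compound 3 differs from compound 1 by methyl in place of hydrogen on an amine nitrogen, which made a step of a number 0.06 log units lower from compound 1 to compound 3 (within the scatter). Compound 4 differs from compound 3 by methyl in place of hydrogen on a saturated chain carbon bound to an amine nitrogen, the same change, at the same place, as that from compound 1 to compound 2; among these compounds it occurs twice. Because the earlier step was a number 0.02 log units higher from compound 1 to compound 2 (within the scatter), a step of similar size is expected in this assay, namely a number 0.02 log units higher from compound 3 to compound 4 (within the scatter). On that basis compound 4 is estimated to give 0.8, with the number expected to fall between 0.55 and 1.05.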

Compound 4, partition coefficient: 1.02
Compound 4: the middle estimate sits 0.22 log units below what was measured, and the stated range covers the measured number.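

In this assay the change of methyl in place of hydrogen on a saturated chain carbon bound to an amine nitrogen gives a number 0.02 log units higher from compound 1 to compound 2 (within the scatter) and, on the second core, a number 0.24 log units higher from compound 3 to compound 4 (within the scatter) and so stays within the usual scatter on both cores, as does the step for methyl in place of hydrogen on an amine nitrogen, a number 0.16 log units higher from compound 2 to compound 4 (within the scatter) on the core of compound 2. These results therefore show no reliable shift in lipophilicity from either change, but two cores cannot show that the first change carries over with a fixed size throughout the series, nor can they separate its two steps from each other. Nothing shown here offers an explanation for these numbers.

Going by these compounds, what stays open is whether a longer chain, such as propyl in place of ethyl, would give a step beyond the scatter. On these data alone, it is also open whether an amine or a carboxylic acid at that place would do so, and whether either step would carry over to other cores.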